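From an Aryl Ether Linker to a Plain Benzyl Group

A few compounds are considered here, and "the series" means these few. Any claim that something is new, unique, unknown or untested is made for them only; others in the source may bear on it.

Compound 2 `Cc1ccccc1OCc1nnc(C(=O)Nc2ccc(CCC(=O)O)cc2)s1` in a functional assay on CHO cells for agonist activity at Free fatty acid receptor 1 (Homo sapiens), read by FLIPR and calcium flux, tested at 1 uM (on this read-out lower numbers stand for an effect already at smaller amounts and higher numbers for an effect only at larger amounts of compound), gives 1520 nM. Compound 1 `Cc1ccc(OCc2nnc(C(=O)Nc3ccc(CCC(=O)O)cc3)s2)cc1` gives 2170 nM, and the step of a 1.4-fold lower number from compound 1 to compound 2 (0.15 log units; within the scatter) shows that the two numbers lie within the scatter of each other, so neither stands apart. Compound 3 `O=C(O)CCc1ccc(NC(=O)c2nnc(Cc3ccccc3)s2)cc1` differs from compound 2 by phenyl in place of 2-methylphenoxy on a saturated chain carbon bound to an aromatic carbon. Among the compounds with values here, no measured step bears on this change: the only step so far merely moves a methyl around the ring and stayed within the scatter. A modest rise in the number is expected for compound 3, namely a 2.0-fold higher number from compound 2 to compound 3 (0.30 log units; within the scatter). The estimate for compound 3 is 3000 nM, with a range from 900 nM to 10000 nM.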

Compound 3, half-maximal effective concentration: 3670 nM
Estimate against measurement, compound 3: 1.2-fold (0.09 log units) below; the range from low to high includes it.
By their numbers in this assay, from the lowest: compounds 2, 1 and 3 (each within the scatter of the next, the first and the last beyond it).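

In this assay, within the data shown here, replacing 2-methylphenoxy with phenyl on this saturated chain carbon gives a 2.4-fold higher number from compound 2 to compound 3 (0.38 log units; beyond the scatter) and so produces the first step in this small set that lies beyond the scatter, though it is only modest. Replacing 4-methylphenoxy in the same way gives a 1.7-fold higher number from compound 1 to compound 3 (0.23 log units; within the scatter) and shows that activity at this level does not require the ether oxygen or the methyl. No measured evidence explains these results. Still open, going by these compounds, is whether the oxygen or the methyl matters more, and whether an amine or a longer chain at this place would change the number.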